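A Methyl on the Piperazine of Compound 3

The compounds below may be only part of what the source reports. "The series", "measured", "known", "first", "only" and "open" are said of these compounds alone.

- compound 1 `CC(C)(C)n1cc2c(n1)C(=O)CC1(CCN(C(=O)c3cc(-c4ccc(Cl)cc4)nc4ccccc34)CC1)O2`: 2330 nM
- compound 2 `CC(C)(C)n1cc2c(n1)C(=O)CC1(CCN(C(=O)c3cc(-c4ccccn4)nc4ccccc34)CC1)O2`: 7720 nM
- compound 3 `CC(C)(C)n1cc2c(n1)C(=O)CC1(CCN(C(=O)c3cc(N4CCNCC4)nc4ccccc34)CC1)O2`: > 10000 nM, a limit and not a number

All three compounds were tested in a functional assay on A549 cells (Homo sapiens) for inhibition, read by MTT assay, with a stated time of 72 h; a higher number here means a weaker inhibitor, a lower number a stronger inhibitor. Compound 3 is the only one of them reported as a limit, at > 10000 nM. Compound 4 `CN1CCN(c2cc(C(=O)N3CCC4(CC3)CC(=O)c3nn(C(C)(C)C)cc3O4)c3ccccc3n2)CC1` has not yet been measured. It differs from compound 3 at one place: methyl in place of hydrogen on an amine nitrogen in a ring. This is methyl in place of hydrogen on an amine nitrogen in a ring, turning piperazin-1-yl into 4-methylpiperazin-1-yl.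

Among the measured compounds shown here, no measured step changes that nitrogen. The nearest evidence comes from the two steps that introduced piperazin-1-yl on the aromatic carbon: an at least 4.2-fold higher number from compound 1 to compound 3 (0.63 log units; beyond the scatter) and an at least 1.2-fold higher number from compound 2 to compound 3 (0.11 log units; that floor lies within the scatter). The series also contains a 3.3-fold higher number from compound 1 to compound 2 (0.52 log units; beyond the scatter) at that same carbon. All of these exchange a whole group, so none of them gives the size of a single methyl change. No step beyond the scatter is therefore expected in this assay, and no direction can be favoured. The expected step is a step that the limit leaves unreadable from compound 3 to compound 4. Compound 4 is estimated at 12000 nM, with an expected range of 6000 nM to 25000 nM, and a report of only a limit would be no surprise.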

Compound 4, half-maximal inhibitory concentration: > 10000 nM
Compound 4: no number, only a limit; the forecaster's own chance of this, stated with the estimate: 65%; the middle value is on the limit's open side.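

In this assay, compound 3 and compound 4 both stop at a limit and not at a number, so the effect of the added methyl on the amine nitrogen cannot be read, and neither its size nor its direction is known: the limit of > 10000 nM in this assay, at which 2 of the 4 values shown sit.

What compound 4 adds is that the methyl does not bring the piperazine series into the measurable range of this assay. Measured against the 4-chlorophenyl of compound 1, the 4-methylpiperazin-1-yl group gives an at least 4.2-fold higher number from compound 1 to compound 4 (0.63 log units; beyond the scatter), so it stays on the weaker side of compound 1, just as piperazin-1-yl did. Against the pyridin-2-yl of compound 2 it gives an at least 1.2-fold higher number from compound 2 to compound 4 (0.11 log units; that floor lies within the scatter), which sets no order between the two compounds.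

The compounds shown leave open how far compound 3 and compound 4 lie past the limit, and so whether the methyl matters at all. They also leave open whether a different group on that nitrogen, such as an acetyl, a benzyl or a longer chain, would give a value that can be read in this assay.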